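Varying the Amide Substituent on a Shared Core

The source may hold more compounds than are shown below. What is called first, only, known or untested is meant among the compounds shown, and "the series" means these compounds.

Compound 1 `CCCCc1oc2ccccc2c1C(=O)c1ccc(OCC(N)=O)cc1`: in a functional assay on MDA-MB-231 cells (Homo sapiens) for antiproliferative activity, read by MTT assay, with a stated time of 24 h (on this read-out lower numbers stand for stronger inhibition and higher numbers for weaker inhibition), compound 1 gives > 50000 nM, a limit of the assay.
Compound 2 `CCCCNC(=O)COc1ccc(C(=O)c2c(CCCC)oc3ccccc23)cc1`: compound 2 gives 34500 nM.
Compound 3 `CCCCc1oc2ccccc2c1C(=O)c1ccc(OCC(=O)N2CCCCC2)cc1`: compound 3 gives > 50000 nM, again a limit of the assay.

Compound 3 therefore stands at the edge of what this assay reports, with no number attached, and it shares that position with one other compound in the set, as the evidence shows: the limit of > 50000 nM in this assay, at which 2 of the 3 values shown sit. The change to compound 4 `CCCCc1oc2ccccc2c1C(=O)c1ccc(OCC(=O)Nc2cccc(OC)c2)cc1` is (3-methoxyphenyl)amino in place of piperidin-1-yl on a carbonyl carbon.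

Among the measured compounds shown here, two measured steps touch the same carbonyl carbon. One is an at least 1.4-fold higher number from compound 2 to compound 3 (0.16 log units; that floor lies within the scatter), and the other is a step that the two limits leave unreadable from compound 1 to compound 3. For the measured compounds named here, neither gives a readable size, and the one step with a number on both ends, an at least 1.4-fold lower number from compound 1 to compound 2 (0.16 log units; that floor lies within the scatter), has a floor that falls within the scatter. Nothing among these compounds reaches well inside the measurable range, so only a weak signal, if any, is expected for compound 4. The step that this estimate means is an at least 1.6-fold lower number from compound 3 to compound 4 (0.22 log units; that floor lies within the scatter), expected to be small and possibly unreadable. The estimated value for compound 4 in this assay is 30000 nM, between 8000 nM and 50000 nM.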

Compound 4, half-maximal inhibitory concentration: > 50000 nM
Compound 4 gave a limit, no number (the forecaster's own chance of this, stated with the estimate: 45%); at least 1.6-fold (0.22 log units) between middle value and limit.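

In this assay compound 4 also stays at a limit of the assay, so (3-methoxyphenyl)amino on the carbonyl carbon gives no number any more than piperidin-1-yl or the plain amino group does: the limit of > 50000 nM in this assay, at which 3 of the 4 values shown sit. Putting 3-methoxyphenyl in place of butyl on the amide-type nitrogen gives an at least 1.4-fold higher number from compound 2 to compound 4 (0.16 log units; that floor lies within the scatter), so this aromatic substituent does not carry the series further into the measurable range, although that floor lies within the scatter. The steps that join compound 4 to compound 1 and to compound 3 have limits at both ends and cannot be read.

As far as these compounds go, how far compound 1, compound 3 and compound 4 lie past the limit remains unknown, and so does any order among them. Also open, from the compounds shown here alone, is whether a chain longer than butyl on the amide-type nitrogen, a morpholine ring on the carbonyl carbon, or a carboxylic acid in place of the amide would bring the value well inside the measurable range of this assay.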